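From methyl to tert-butyl on the shared core

The source may report more compounds than this note shows. Statements on the series, on what has been measured and on what is new or still open speak of the compounds shown alone.

In a functional assay on MDA-MB-231 cells (Homo sapiens) for antiproliferative activity, with a stated time of 4 days (a lower number here means a stronger inhibitor, a higher number a weaker inhibitor), compound 1 (`COc1ccc(-c2[nH]c3cc(Cl)c(C)cc3c2C=O)cc1`) gives 26 nM, and compound 2 (`COc1ccc(-c2[nH]c3ccc(C)cc3c2C=O)cc1`) gives 86 nM. Compound 2 therefore holds the higher of the two numbers, making it the weaker inhibitor of this pair.

Compound 3 (`COc1ccc(-c2[nH]c3ccc(C(C)(C)C)cc3c2C=O)cc1`) keeps the frame of compound 2 but carries tert-butyl in place of methyl on an aromatic carbon. Within the data shown here, the only measured step is a 3.3-fold higher number from compound 1 to compound 2 (0.52 log units; beyond the scatter), for hydrogen in place of chloro on an aromatic carbon. Among the measured compounds shown here, it bears on the new change only indirectly, as no measured compound varies the methyl group itself. It does show that a single substituent change on the core can move the number in this assay beyond the scatter. With so little evidence, a step of modest size toward a higher number is expected, though the direction is uncertain. The expected change is a 1.7-fold higher number from compound 2 to compound 3 (0.24 log units; within the scatter). For compound 3 the estimated value is 150 nM, with an expected range from 40 nM to 600 nM.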

Compound 3, half-maximal inhibitory concentration: 280 nM
Compound 3: middle estimate off by 1.9-fold (0.27 log units), on the low side; measured number inside the range.
By their numbers in this assay, from the lowest: compound 1; then compound 2; then compound 3.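

In this assay, among these compounds, replacing methyl with tert-butyl gives a 3.3-fold higher number from compound 2 to compound 3 (0.51 log units; beyond the scatter), the first measured change at this aromatic carbon, and it makes compound 3 the weaker inhibitor of this pair. The earlier step concerned chloro and hydrogen at a different carbon of the shared core, so this result adds that the number also responds to the group held at this position, even when methyl of 1 heavy atom gives way to tert-butyl of 4 heavy atoms, all of them carbon, with no ring, hydrogen-bond donor, hydrogen-bond acceptor or net charge entering or leaving. Nothing available accounts for why this exchange raises the number.

Among the compounds shown here, with only two groups compared here, a single pair cannot show whether the number climbs steadily with the size of the group or whether tert-butyl is a special case, and an ethyl or isopropyl group at this carbon would help to separate the two, as would an amine or a methoxy group. As far as these compounds go, it also remains open whether chloro would produce a comparable step on the frame of compound 3 as it does on the frame of compound 2.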